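From 4-(tert-butyl)benzyl to 3-chlorobenzyl in a flat series

This account rests on a few compounds, and the source may have more. Where it says the series, first, only, none or still open, it means among the compounds named here.

Three related compounds have been tested in a functional assay on A549 cells (Homo sapiens) for cytotoxicity, read by MTT assay, with a stated time of 72 h; a higher number here means a weaker inhibitor, a lower number a stronger inhibitor. Compound 1 `CCN(CC)Cc1ccc2nc(NC(=O)N/N=C/c3cn(Cc4ccc(C(C)(C)C)cc4)c4ccccc34)sc2c1` gives 1710 nM, compound 2 `CN(C)Cc1ccc2nc(NC(=O)N/N=C/c3cn(Cc4ccc(C(C)(C)C)cc4)c4ccccc34)sc2c1` gives 1850 nM, and compound 3 `Cc1ccc(Cn2cc(/C=N/NC(=O)Nc3nc4ccc(CN5CCC(C)CC5)cc4s3)c3ccccc32)cc1` gives 2180 nM. Compound 2 therefore stands among numbers that all lie close together, within the scatter of its two neighbours, so no order can be read from them.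

The next compound, compound 4 `CN(C)Cc1ccc2nc(NC(=O)N/N=C/c3cn(Cc4cccc(Cl)c4)c4ccccc34)sc2c1`, keeps the dimethylamino group of compound 2 and changes the other end of the molecule: 3-chlorophenyl in place of 4-(tert-butyl)phenyl on a saturated chain carbon bound to an aromatic nitrogen. In words, 3-chlorophenyl comes in place of 4-(tert-butyl)phenyl on a saturated chain carbon bound to an aromatic nitrogen.

Within the data shown here, no measured step tests this exact change. Among the measured compounds shown here, the one measured step, a 1.1-fold higher number from compound 1 to compound 2 (0.03 log units; within the scatter), swaps diethylamino for dimethylamino at a different place, and it stays within the scatter. The closest hint carries another group at this place and differs from compound 2 elsewhere too: compound 3 still gives 2180 nM. With so little evidence, no shift in either direction can be argued, and the expected result is a 1.1-fold higher number from compound 2 to compound 4 (0.03 log units; within the scatter), with real uncertainty. Compound 4 is estimated at 2000 nM, with an expected range from 700 nM to 6000 nM.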

Compound 4, half-maximal inhibitory concentration: 1240 nM
The estimate for compound 4 lay 1.6-fold (0.21 log units) above the measured number; measured number inside the range.
By their numbers in this assay, from the lowest: compounds 4, 1, 2 and 3 (each within the scatter of the next).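

Among these compounds, this is the first step measured at the place on a saturated chain carbon bound to an aromatic nitrogen, and in this assay it reads as a 1.5-fold lower number from compound 2 to compound 4 (0.17 log units; within the scatter) and so cannot be told apart from repeat-measurement noise. The exchange is not a trivial one on paper: the 10 heavy atoms of 4-(tert-butyl)phenyl, all carbon, give way to the 7 of 3-chlorophenyl, which bring in a chlorine, yet compound 2 and compound 4 remain indistinguishable in this test, so these two aromatic groups can be exchanged here without a readable effect on the number. No supporting measurement bears on this result, so it stands as an observation without an explanation.

From the compounds shown here alone, the two groups compared here are both substituted phenyl rings without hydrogen-bond donors or acceptors, so it remains open whether a phenyl carrying a carboxylic acid or an amine, or a plain methyl in place of the whole benzyl group, would move the number beyond the scatter. Going by these compounds, it is also open whether 3-chlorobenzyl would read the same alongside diethylamino at the other end of the molecule.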